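Solubility notes: from compound 2 to compound 4

A few compounds are considered here, and "the series" means these few. Any claim that something is new, unique, unknown or untested is made for them only; others in the source may bear on it.

Measured in a physicochemical assay for solubility, read by LC-MS, using the shake flask method, measured as thermodynamic solubility, with a stated time of 24 h, at pH 6.5; on this read-out higher numbers stand for higher solubility and lower numbers for lower solubility:
- compound 1 `O=C(O)c1ccc(-n2cc(CO[C@H]3O[C@H](CO)[C@@H](O)[C@H](O)[C@@H]3O)nn2)cc1`: > 3000 ug/mL
- compound 2 `Nc1ccc(-n2cc(CO[C@H]3O[C@H](CO)[C@@H](O)[C@H](O)[C@@H]3O)nn2)cc1`: > 2000 ug/mL
- compound 3 `O=[N+]([O-])c1ccc(-n2cc(CO[C@H]3O[C@H](CO)[C@@H](O)[C@H](O)[C@@H]3O)nn2)cc1`: 2600 ug/mL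

Compound 2 is known only as a limit, > 2000 ug/mL. Compound 1 is likewise only a limit, > 3000 ug/mL. Compound 4 `OC[C@H]1O[C@H](OCc2cn(-c3ccc(F)cc3)nn2)[C@@H](O)[C@@H](O)[C@@H]1O` differs from compound 2 as follows: fluoro in place of amino on an aromatic carbon. This places fluoro in place of amino on an aromatic carbon, para to a large group. The related changes at this place are a step that the two limits leave unreadable from compound 1 to compound 2, a step that the limit leaves unreadable from compound 2 to compound 3 and an at least 1.1-fold lower number from compound 1 to compound 3 (0.06 log units; that floor lies within the scatter). None of them gives a readable step beyond the scatter, so no step beyond the scatter is expected in this assay, and no direction is expected either. Going by the values given here, the only actual number is that of compound 3, 2600 ug/mL, and the expectation leans on it. The expected change is a step that the limit leaves unreadable from compound 2 to compound 4. Compound 4 is estimated at 2500 ug/mL, with an expected range of 1000 ug/mL to 5000 ug/mL.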

Compound 4, solubility: > 3000 ug/mL
Compound 4: no number, only a limit; the forecaster's own chance of this, stated with the estimate: 40%; middle value at least 1.2-fold (0.07 log units) from the limit.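

In this assay compound 4 gives > 3000 ug/mL, which is a limit and not a number. Fluoro, para to a large group, therefore joins the groups tolerated at this place without a drop in the read-out, and the one readable step is an at least 1.1-fold higher number from compound 3 to compound 4 (0.06 log units; that floor lies within the scatter), while the steps to compound 4 from compound 1 and from compound 2 cannot be read. A second compound now stands at the same limit: the limit of > 3000 ug/mL in this assay, at which 2 of the 4 values shown sit.

As far as these compounds go, the order of compound 1, compound 2 and compound 4 stays open. Also open, from the compounds shown here alone, is whether a methyl, a methoxy or a longer alkyl chain at this place would give a number rather than a limit.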